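The source may hold more compounds than are shown below. What is called first, only, known or untested is meant among the compounds shown, and "the series" means these compounds.

Measured so far:
- compound 1, `C=C(C)[C@@H]1CC=C(C)/C(=N/NC(=O)Nc2nnc(-c3ccc(OC)cc3)o2)C1`, in a functional assay on the whole organism (strain Swiss albino) with Mus musculus as the target, with a stated time of 4 h (on this read-out higher numbers stand for an effect only at larger amounts of compound and lower numbers for an effect already at smaller amounts), compound 1 gives 300 mg/kg
- compound 2, `CC(C)=CC/C=C(/C)C/C=N/NC(=O)Nc1nnc(-c2ccc(Cl)cc2)o1`, in this assay compound 2 gives 300 mg/kg
- compound 3, `CC(C)=CC/C=C(/C)C/C=N/NC(=O)Nc1nnc(-c2ccc([N+](=O)[O-])cc2)o1`, in this assay compound 3 gives 300 mg/kg

On these numbers compound 3 stands level with compounds 1 and 2: all three sit at the same value within the scatter, so none of them can be called more or less active than another.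

The next compound is compound 4, `CC(C)=CC/C=C(/C)C/C=N/NC(=O)Nc1nnc(-c2ccc(F)cc2)o1`. It differs from compound 3 in one place only: fluoro in place of nitro on an aromatic carbon. Going by the values given here, one measured step bears on this: the exchange at the same aromatic carbon that led from compound 2 to compound 3 gave no change at the digits printed from compound 2 to compound 3 (within the scatter). That step was within the scatter, so exchanging one group for another at this carbon has so far not moved the read-out.

For compound 4 no step beyond the scatter is therefore expected, with no change at the digits printed from compound 3 to compound 4 (within the scatter). Compound 4 is expected to give about 300 mg/kg in this assay, with a likely range from 150 mg/kg to 600 mg/kg.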

Compound 4, minimum effective dose: 300 mg/kg
For compound 4 middle estimate and measured number coincide at the digits printed; the measured number falls inside the stated range.
By their numbers in this assay, from the lowest: compounds 1, 2, 3 and 4 (each within the scatter of the next).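

The exchange of 4-nitrophenyl for 4-fluorophenyl gives no change at the digits printed from compound 3 to compound 4 (within the scatter) in this assay and leaves the aromatic carbon's tolerance unbroken. Fluoro in place of chloro likewise gives no change at the digits printed from compound 2 to compound 4 (within the scatter) at this carbon, so chloro, nitro and fluoro now all read alike here, and the swap between the two halogens adds a second direct comparison to the one involving nitro. Nothing measured here accounts for this flat result.

Still open, from the compounds shown here alone, is whether an amine or a carboxylic acid on this same aromatic carbon would read alike or would shift the minimum effective dose. Also open, going by these compounds, is whether a change elsewhere on the shared core, such as a longer chain, would move this number at all.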